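This account rests on a few compounds, and the source may have more. Where it says the series, first, only, none or still open, it means among the compounds named here.

Working notes on the series. In a functional assay on SW-620 cells (Homo sapiens) for cytotoxicity, read by MTT assay, with stated times of 4 h and 72 h, tested at 5 uM (a higher number here means a weaker inhibitor, a lower number a stronger inhibitor), compound 1 `Cc1cc(Nc2ccc(C(=O)/C=C/c3ccc4ccccc4c3)cc2)n2nc(SCc3cccc(Br)c3)nc2n1` gives 270 nM, the lowest of the three numbers. Compound 2 `Cc1cc(Nc2ccc(C(=O)/C=C/c3ccc4ccccc4c3)cc2)n2nc(SCc3ccccc3)nc2n1` gives 300 nM and compound 3 `Cc1cc(Nc2ccc(C(=O)/C=C/c3ccc4ccccc4c3)cc2)n2nc(SCc3ccc(Br)cc3)nc2n1` gives 370 nM in this assay; the steps of a 1.1-fold higher number from compound 1 to compound 2 (0.05 log units; within the scatter), a 1.4-fold higher number from compound 1 to compound 3 (0.14 log units; within the scatter) and a 1.2-fold higher number from compound 2 to compound 3 (0.09 log units; within the scatter) all stay within the scatter, so the benzyl group may be changed here without a clear effect on the number.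

Compound 4 `COc1ccc(CSc2nc3nc(C)cc(Nc4ccc(C(=O)/C=C/c5ccc6ccccc6c5)cc4)n3n2)cc1` differs from compound 1 by 4-methoxyphenyl in place of 3-bromophenyl on a saturated chain carbon bound to a sulfur, that is, 3-bromobenzyl to 4-methoxybenzyl. Going by the values given here, no measured compound carries a methoxy group, so the steps among compounds 1, 2 and 3 are the only guide, and they suggest a step in this assay for compound 4 no larger than the scatter. The estimate for compound 4 is therefore 320 nM, between 150 nM and 700 nM, an expected step of a 1.2-fold higher number from compound 1 to compound 4 (0.07 log units; within the scatter).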

Compound 4, half-maximal inhibitory concentration: 250 nM
For compound 4 the middle estimate is 1.3-fold (0.11 log units) above the measured one; measured number inside the range.
By their numbers in this assay, from the lowest: compounds 4, 1, 2 and 3 (each within the scatter of the next).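

With 4-methoxybenzyl at this position, the number in this assay stays within the scatter of all three earlier compounds: the steps are a 1.1-fold lower number from compound 1 to compound 4 (0.03 log units; within the scatter) and a 1.2-fold lower number from compound 2 to compound 4 (0.08 log units; within the scatter) and a 1.5-fold lower number from compound 3 to compound 4 (0.17 log units; within the scatter). So a methoxy group, which brings a hydrogen-bond acceptor that the bromo and hydrogen compounds lack, gives no clear change on this aromatic carbon. No supporting data bear on why the number holds.

Still open, from the compounds shown here alone, is whether an amine or a carboxylic acid on the benzyl group, or a longer chain on the sulfur, would move the number beyond the scatter.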